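Adding an ester chain to the hydroxy of compound 2

The source may report more compounds than this note shows. Statements on the series, on what has been measured and on what is new or still open speak of the compounds shown alone.

Compound 1 `COc1c(Br)cc(C=O)c(O)c1Br` gives 806000 nM
Compound 2 `COc1c(Br)cc(CO)c(O)c1Br` gives > 16000 nM as a limit

Both readings come from an ADME assay on BAEC cells (Bos taurus) for cytotoxicity, read by MTT assay, with a stated time of 2 days (on this read-out higher numbers stand for weaker inhibition and lower numbers for stronger inhibition), and give the only data so far. In this assay compound 1 has a full number of 806000 nM as its reading. Compound 2 has only a limit of > 16000 nM and no exact number.

Compound 3 `COC(=O)COc1c(CO)cc(Br)c(OC)c1Br` differs from compound 2 in one place, and (methoxycarbonyl)methyl in place of hydrogen on an oxygen on an aromatic ring is the whole change. Put simply, a hydroxy becomes (methoxycarbonyl)methoxy.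

Going by the values given here, the one measured step is a step that the limit leaves unreadable from compound 1 to compound 2 and it concerns hydroxymethyl in place of formyl on an aromatic carbon. It does not touch this oxygen, and its size cannot be read, so it offers nothing to carry over. Among the compounds with values here, no measurement yet shows what a change at this oxygen does.

Within the data shown here, the expectation leans on compound 1 at 806000 nM as the only full number in hand, and it assumes that inhibition stays weak. The expected step that the limit leaves unreadable from compound 2 to compound 3 is therefore a rough estimate with no firm direction. Compound 3 is expected near 100000 nM with an estimated range from 20000 nM to 500000 nM. A limit in place of a full number remains a fair possibility for compound 3.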

Compound 3, half-maximal inhibitory concentration: > 26000 nM
Compound 3 was reported as a limit (the forecaster's own chance of this, stated with the estimate: 50%); the middle value does not contradict the limit.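

In this assay compound 2 gives > 16000 nM, which is a limit and not a number. Compound 3 gives > 26000 nM, also a limit. Going by these compounds alone, no step between compound 2 and compound 3 can be read from these two limits. The compounds shown leave open whether, and in which direction, replacing hydroxy with (methoxycarbonyl)methoxy changes the reading.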